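This account rests on a few compounds, and the source may have more. Where it says the series, first, only, none or still open, it means among the compounds named here.

Compound 3 `COc1cccc(OC)c1OCCNCCOc1ccccc1OCc1cccc(C)c1` gives 0.2 nM in an assay on CHO cells for displacement of a labelled ligand from Alpha-1D adrenergic receptor (Homo sapiens) (a lower number here means a stronger inhibitor, a higher number a weaker inhibitor), the highest of the three numbers recorded so far. Compound 2 `COc1cccc(OC)c1OCCNCCOc1ccccc1OCc1ccccc1C` gives 0.126 nM in this assay, and compound 1 `COc1cccc(OC)c1OCCNCCOc1ccccc1OCc1ccc(Cl)cc1` gives 0.0316 nM. The step of a 1.6-fold higher number from compound 2 to compound 3 (0.20 log units; within the scatter) lies within the scatter, whereas a 6.3-fold higher number from compound 1 to compound 3 (0.80 log units; beyond the scatter) and a 4.0-fold higher number from compound 1 to compound 2 (0.60 log units; beyond the scatter) both lie beyond it, so compound 1 holds the lowest number of the set. Compound 4 `COc1cccc(OC)c1OCCNCCOc1ccccc1OCc1ccc(C)cc1` differs from compound 3 by 4-methylphenyl in place of 3-methylphenyl on a saturated chain carbon bound to an oxygen on an aromatic ring. Among the compounds with values here, no measured step brings a methyl group to the position entered here; the only step between methyl positions, a 1.6-fold higher number from compound 2 to compound 3 (0.20 log units; within the scatter), is within the scatter, which gives little ground for a large shift from moving the methyl alone. Compound 1, however, bears a 4-chlorophenyl on the saturated chain carbon bound to an oxygen on an aromatic ring and reaches 0.0316 nM. A lower number than compound 3 is therefore expected for compound 4, a step of roughly a 2.0-fold lower number from compound 3 to compound 4 (0.30 log units; within the scatter). Compound 4 is estimated at 0.1 nM, with a range from 0.035 nM to 0.3 nM.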

Compound 4, inhibition constant: 0.0631 nM
Beside the measured number, compound 4's estimate is 1.6-fold (0.20 log units) above it; the range from low to high includes it.
By their numbers in this assay, from the lowest: compounds 1, 4, 2 and 3 (each within the scatter of the next, the first and the last beyond it).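

Within the data shown here, the methyl position on this aryl group registers in this assay: with the atoms unchanged, 4-methylphenyl in place of 3-methylphenyl gives a 3.2-fold lower number from compound 3 to compound 4 (0.50 log units; beyond the scatter), the first step between methyl positions to clear the scatter. The 2-methylphenyl compound does not separate from either neighbour, and a 2.0-fold lower number from compound 2 to compound 4 (0.30 log units; within the scatter) adds to the earlier within-scatter step, so the three methyl positions give no clean ranking. Methyl in place of chloro on an aromatic carbon gives a 2.0-fold higher number from compound 1 to compound 4 (0.30 log units; within the scatter), so 4-methylphenyl and 4-chlorophenyl are not distinguished here.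

No evidence at hand accounts for these steps. On these data alone, whether a methoxy, ethyl or fluoro group in place of the methyl of 4-methylphenyl would stay within the scatter of compound 4 remains open.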